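A few compounds are considered here, and "the series" means these few. Any claim that something is new, unique, unknown or untested is made for them only; others in the source may bear on it.

In an ADME assay on microsomes from liver (Homo sapiens) for metabolic stability, tested at 2.5 uM (on this read-out higher numbers stand for fast clearance and lower numbers for slow clearance), compound 2 `O=S(=O)(c1cc(Cl)cc(Cl)c1)c1cnc2cc(F)ccc2c1-c1cccc(F)c1` gives 0.41 mL/min, the lower of the two values measured, whereas compound 1 `COc1ccc(-c2c(S(=O)(=O)c3ccc(C)c(C)c3)cnc3cc(F)ccc23)cc1` gives 4.13 mL/min, a gap beyond the usual scatter. Compound 3 `Cc1ccc(S(=O)(=O)c2cnc3cc(F)ccc3c2-c2cccc(F)c2)cc1C` carries 3,4-dimethylphenyl in place of 3,5-dichlorophenyl on a sulfonyl sulfur. Among the measured compounds shown here, no pair of measured compounds differs by exactly this change, yet compound 1 with the same 3,4-dimethylphenyl group gives 4.13 mL/min. For compound 3 a rise in clearance is therefore expected, of about a 4.9-fold higher number from compound 2 to compound 3 (0.69 log units; beyond the scatter). In this assay compound 3 is estimated at 2 mL/min, with a range from 0.8 mL/min to 5 mL/min.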

Compound 3, intrinsic clearance in a liver preparation (reported as CLH), per the amount of preparation that the assay uses: 3.71 mL/min
Compound 3: the middle estimate sits 1.9-fold (0.27 log units) below what was measured; the measured number falls inside the stated range.
By their numbers in this assay, from the lowest: compound 2; then compounds 3 and 1 (each within the scatter of the next).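

In this assay the change on the sulfonyl sulfur, 3,4-dimethylphenyl in place of 3,5-dichlorophenyl, now has a direct step (a 9.0-fold higher number from compound 2 to compound 3 (0.96 log units; beyond the scatter)), which lies beyond the scatter. The change on the aromatic carbon, 3-fluorophenyl in place of 4-methoxyphenyl, gives a step within the scatter (a 1.1-fold lower number from compound 1 to compound 3 (0.05 log units; within the scatter)). Only the sulfonyl change therefore gives a clear difference here.

Nothing given explains this step. Going by these compounds, it remains open which methyl group matters, and whether a phenyl bearing an amine or a nitrile on that sulfur would read like compound 2 or compound 3.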